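Methyl on a ring carbon of compound 2

The source may hold more compounds than are shown below. What is called first, only, known or untested is meant among the compounds shown, and "the series" means these compounds.

compound 1 `C[C@]1(O)C[C@](c2ccc(OC(F)(F)F)cc2)([C@H](O)c2ccccn2)C1` gives 50 mL/min/kg
compound 2 `O[C@H](c1ccccn1)[C@]1(c2ccc(C(F)(F)F)cc2)C[C@@H](O)C1` gives 33.3 mL/min/kg

In an ADME assay on liver for metabolic stability, with Liver microsome (Homo sapiens) as the target, read by LC-MS, using microsomes, with a stated time of 5 h (a lower number here means slower removal, a higher number faster removal of the compound), compound 2 (33.3 mL/min/kg) stands within the scatter of compound 1 (50 mL/min/kg). Compound 3 `C[C@]1(O)C[C@@](c2ccc(C(F)(F)F)cc2)([C@H](O)c2ccccn2)C1` departs from compound 2 by methyl in place of hydrogen on a saturated ring carbon. Within the data shown here, no measured pair isolates this change. Compound 1 also carries that methyl and gives 50 mL/min/kg, so a small rise, not beyond the scatter, is expected. The expected step is a 1.2-fold higher number from compound 2 to compound 3 (0.08 log units; within the scatter). For compound 3 the estimate is 40 mL/min/kg, with an expected range of 22 mL/min/kg to 70 mL/min/kg.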

Compound 3, clearance: 50 mL/min/kg
For compound 3 the middle estimate is 1.3-fold (0.10 log units) below the measured one; the range from low to high includes it.
By their numbers in this assay, from the lowest: compounds 2, 1 and 3 (each within the scatter of the next).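

In this assay, among these compounds, the methyl on a saturated ring carbon of the four-membered ring now stands as an isolated change, with a 1.5-fold higher number from compound 2 to compound 3 (0.18 log units; within the scatter) as the first single-change step. At this position, the methyl therefore gives a step that stays within the scatter. Nothing measured here gives a reason for this step. Still open, from the compounds shown here alone, is how a larger or charged group on the same ring carbon, such as an ethyl chain or an amine, would read in this assay.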